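The source may hold more compounds than are shown below. What is called first, only, known or untested is meant among the compounds shown, and "the series" means these compounds.

Measured compounds:
compound 1, `NC(=O)CCn1nc(-c2ccccc2)ccc1=O`: -2.8%
compound 2, `N=C(S)CCn1nc(-c2ccccc2)ccc1=O`: 53.7%
compound 3, `Cc1ccc(=O)n(CCC(=N)S)n1`: 73.9%

All three were tested in a functional assay on the whole organism (stomach) for inhibition, with Rattus norvegicus as the target, at a dose of 100 mg/kg by the intraduodenal route; a higher number here means more inhibition at the dose given (going by the name of the read-out), a lower number less inhibition. Compound 3 gives the highest number of the three; compound 2 stands nearest to it and compound 1 furthest off. Compound 2 and compound 3 share the chain ending and differ only in the core: methyl in place of phenyl on an aromatic carbon. The step this makes is modest: a number 20.2 percentage points higher from compound 2 to compound 3 (beyond the scatter). Compound 2 and compound 1 share the core of compound 2 and differ in the chain ending: a group of 3 heavy atoms (1 carbon, 1 nitrogen, 1 oxygen; no ring) in place of a group of 3 heavy atoms (1 carbon, 1 nitrogen, 1 sulfur; no ring), on a saturated chain carbon, two bonds along the chain from an aromatic nitrogen. The step here is large: a number 56.5 percentage points lower from compound 2 to compound 1 (beyond the scatter).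

For the measured compounds named here, compound 1 and compound 3 differ in both places at once and no single step joins them; their values alone show compound 1 far beneath compound 3.

Compound 4, `Cc1ccc(=O)n(CCC(N)=O)n1`, is not yet measured. It differs from compound 3 by a group of 3 heavy atoms (1 carbon, 1 nitrogen, 1 oxygen; no ring) in place of a group of 3 heavy atoms (1 carbon, 1 nitrogen, 1 sulfur; no ring), on a saturated chain carbon, two bonds along the chain from an aromatic nitrogen. Going by the values given here, this is the same change as the one from compound 2 to compound 1, at a place worded the same in both cases, and it occurs twice. For compound 4 a step of about the same size is expected, a number 56.9 percentage points lower from compound 3 to compound 4 (beyond the scatter), set beside the earlier one, a number 56.5 percentage points lower from compound 2 to compound 1 (beyond the scatter). That expectation rests on a single measured pair, compound 2 to compound 1, so it is held loosely. Compound 4 is expected to give 17% in this assay, within a range from -5% to 40%.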

Compound 4, a percentage reported as inhibition, in the whole organism at one dose (the size of the read-out at that dose, not a potency): -2.9%
Compound 4: the middle estimate sits 19.9 percentage points above what was measured; the range from low to high includes it.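

The new step, a number 76.8 percentage points lower from compound 3 to compound 4 (beyond the scatter), runs the same way as the earlier one on the core of compound 2, so in this assay carbamoyl in place of the sulfur-bearing ending goes with a lower number on both cores, but the size of the step does not carry over: the same change on two cores in this assay, a number 56.5 percentage points lower (beyond the scatter) from compound 2 to compound 1 and a number 76.8 percentage points lower (beyond the scatter) from compound 3 to compound 4, 20.3 percentage points apart, beyond the scatter of two such steps. Seen from the other place, methyl in place of phenyl goes with a higher number only when the sulfur-bearing ending is present, while with carbamoyl the step is a number 0.1 percentage points lower from compound 1 to compound 4 (within the scatter), so the two places do not add up independently in these compounds: the same change on two cores in this assay, a number 20.2 percentage points higher (beyond the scatter) from compound 2 to compound 3 and a number 0.1 percentage points lower (within the scatter) from compound 1 to compound 4, 20.3 percentage points apart, beyond the scatter of two such steps. This rests on two pairs of compounds read at a single dose; it gives the direction of the change on these two cores only, and it shows neither why the step sizes differ nor how the change would behave on any other core.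

Still open, on these data alone, is how the chain behaves with a carboxylic acid, a nitrile or an amine in place of carbamoyl, and whether a longer chain keeps the same pattern. Also open, as far as these compounds go, is whether an ethyl group or a chlorine on the aromatic carbon that carries the methyl or phenyl would fall in line with compound 2 or compound 3.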